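The compounds below may be only part of what the source reports. "The series", "measured", "known", "first", "only" and "open" are said of these compounds alone.

Of the compounds shown here, two sharing one core have been tested in an ADME assay on WI-38 cells (Homo sapiens) for cytotoxicity, read by sulforhodamine B assay, with a stated time of 24 h; a higher number here means a weaker inhibitor, a lower number a stronger inhibitor. Compound 1 `O=C1Nc2ccc(S(=O)(=O)N3CCOCC3)cc2/C1=N/c1cccc(C(F)(F)F)c1` gives 226000 nM and compound 2 `O=C1Nc2ccc(S(=O)(=O)N3CCOCC3)cc2/C1=N/c1ccc(/N=C2\C(=O)Nc3ccc(S(=O)(=O)N4CCOCC4)cc32)cc1` gives 203000 nM. These two values lie within the usual scatter of each other, so compound 1 stands level with compound 2. Compound 3 `CC(=O)c1cccc(/N=C2\C(=O)Nc3ccc(S(=O)(=O)N4CCOCC4)cc32)c1` has not yet been measured. It differs from compound 1 in one place: acetyl in place of trifluoromethyl on an aromatic carbon, meta to a large group. Within the data shown here, no measured pair shows this change directly, and the only guide is that the structurally different compound 2 still gives 203000 nM. The expected step in this assay is a 1.3-fold lower number from compound 1 to compound 3 (0.10 log units; within the scatter), which would be no change beyond the scatter. For compound 3 the estimated value is 180000 nM, with an expected range from 70000 nM to 400000 nM.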

Compound 3, half-maximal inhibitory concentration: 177000 nM
Compound 3: the middle estimate sits 1.0-fold (0.01 log units) above what was measured; low and high end bracket the measured number.
By their numbers in this assay, from the lowest: compounds 3, 2 and 1 (each within the scatter of the next).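

In this assay, among these compounds, the swap from 3-(trifluoromethyl)phenyl to 3-acetylphenyl gives a 1.3-fold lower number from compound 1 to compound 3 (0.11 log units; within the scatter), the first direct reading of a change at this position. Acetyl brings a hydrogen-bond acceptor and a double bond outside the aromatic rings, while trifluoromethyl has neither, yet the number stays within the scatter for this one pair on this one core. Nothing measured here bears on why the two groups read alike.

On these data alone, whether an amine, a carboxylic acid or a longer chain on the same aromatic carbon would shift the number beyond the scatter remains open. With compound 3 at 177000 nM, the compounds shown also offer no example of a value clearly apart from the others in this assay.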